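A few compounds are considered here, and "the series" means these few. Any claim that something is new, unique, unknown or untested is made for them only; others in the source may bear on it.

Series in a functional assay on K562 cells (Homo sapiens) for antiproliferative activity, read by MTT assay, with a stated time of 72 h; on this read-out higher numbers stand for weaker inhibition and lower numbers for stronger inhibition:
- compound 1 `COc1cc(-n2ncnc2-c2ccc(C)cc2)cc(OC)c1OC`: > 10000 nM
- compound 2 `CCOc1cccc(-c2ncnn2-c2cc(OC)c(OC)c(OC)c2)c1`: > 10000 nM
- compound 3 `COc1cc(-c2ncnn2-c2ccccc2)cc(OC)c1OC`: > 10000 nM

Each of these entries is a limit of the assay, not a number. Compound 1 stands with the other two at the limit of > 10000 nM in this assay, at which 3 of the 3 values shown sit. The next compound is compound 4 `CCOc1ccc(-c2ncnn2-c2cc(OC)c(OC)c(OC)c2)cc1`, with ethoxy in place of methyl on an aromatic carbon, para to a large group (ethoxy in place of methyl on an aromatic carbon). Among the compounds with values here, no measured step exists, so the expectation rests on this change alone. Compound 2 also carries ethoxy and gives > 10000 nM, again a limit, so a further limit remains quite possible. A move towards stronger inhibition of uncertain size is nevertheless expected, with the estimated step of an at least 6.6-fold lower number from compound 1 to compound 4 (0.82 log units; beyond the scatter). For compound 4 the estimated value is 1500 nM, with an expected range of 50 nM to 10000 nM.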

Compound 4, half-maximal inhibitory concentration: 20 nM
For compound 4 the middle estimate is 75-fold (1.88 log units) above the measured one; measured number below the stated range.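

In this assay, ethoxy in place of methyl on an aromatic carbon, para to a large group, gives an at least 500-fold lower number from compound 1 to compound 4 (2.69 log units; beyond the scatter), and this step rests on a limit for compound 1. Compound 2, which carries ethoxy at another place on that ring, stays at the limit of > 10000 nM, so ethoxy alone is not enough and its place counts in this pair. Only compound 4 gives a number rather than a limit: the limit of > 10000 nM in this assay, at which 3 of the 4 values shown sit.

The compounds shown leave open whether methoxy, propoxy or an amine at this place would keep the gain. They also leave open whether the oxygen or the two-carbon chain of ethoxy carries it.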